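Aminothiophene variant of the ketone aryl group

The source may hold more compounds than are shown below. What is called first, only, known or untested is meant among the compounds shown, and "the series" means these compounds.

For the measured compounds named here, compound 2 `COc1ccc(-c2cc3ccccc3nc2/C=C/C(=O)c2ccsc2)cc1` holds the highest of the two numbers so far in a functional assay on A549 cells (Homo sapiens) for antiproliferative activity, read by XTT assay, with a stated time of 72 h; a lower number here means a stronger inhibitor, a higher number a weaker inhibitor: compound 2 gives 8210 nM. Its nearest neighbour is compound 1 `COc1ccc(-c2cc3ccccc3nc2/C=C/C(=O)c2ccco2)cc1`, which in this assay gives 6130 nM; the step of a 1.3-fold higher number from compound 1 to compound 2 (0.13 log units; within the scatter) is within the scatter, so the two compounds cannot be ordered.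

Compound 3 `COc1ccc(-c2cc3ccccc3nc2/C=C/C(=O)c2sccc2N)cc1` is not yet measured. It differs from compound 2 by 3-aminothiophen-2-yl in place of thiophen-3-yl on a carbonyl carbon. Going by the values given here, the only measured step that bears on this place is the aryl swap from compound 1 to compound 2, which stayed within the scatter. Among the compounds with values here, no measured pair shows the effect of the amino group, so the data give no direction for it. The working expectation is therefore no step beyond the scatter, a 1.2-fold lower number from compound 2 to compound 3 (0.07 log units; within the scatter), with a wide range to cover the untested amino substituent. Compound 3 is estimated at 7000 nM in this assay, between 2500 nM and 20000 nM.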

Compound 3, half-maximal inhibitory concentration: > 10000 nM
Compound 3: only a limit was reported (the forecaster's own chance of this, stated with the estimate: 5%); middle value at least 1.4-fold (0.15 log units) away from the limit.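

In this assay compound 3 gives > 10000 nM, which is a limit of the assay and not a number, so this change at the carbonyl carbon has only a floor for its size: the limit of > 10000 nM in this assay, at which 1 of the 3 values shown sits. The two new steps read as an at least 1.2-fold higher number from compound 2 to compound 3 (0.08 log units; that floor lies within the scatter) and an at least 1.6-fold higher number from compound 1 to compound 3 (0.21 log units; that floor lies within the scatter), so neither can be called a real loss. For the compounds shown here, still, the first group with a hydrogen-bond donor gives no sign of a lower number at this position.

As far as these compounds go, the true size of the step behind the limit stays open, as does whether the amino group or the change of thiophene attachment carries it, since compound 3 differs in both at once. An unsubstituted thiophen-2-yl group, or a methoxy group in place of the amine on the same ring, would separate the two.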